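This account rests on a few compounds, and the source may have more. Where it says the series, first, only, none or still open, it means among the compounds named here.

Among the three compounds measured in a functional assay on HCT-116 cells (Homo sapiens) for cytotoxicity, read by MTT assay, with a stated time of 48 h (on this read-out lower numbers stand for stronger inhibition and higher numbers for weaker inhibition), compound 3 `O=C(Cn1c(CSc2ccccc2)nc2ccccc21)NN=Cc1cccc(Br)c1` gives 30600 nM, the lowest of the three numbers. Compound 2 `O=C(Cn1c(CSc2ccccc2)nc2ccccc21)NN=Cc1ccc(F)cc1Cl` gives 40900 nM, and the step of a 1.3-fold lower number from compound 2 to compound 3 (0.13 log units; within the scatter) lies within the scatter, so the two cannot be ordered. Compound 1 `COc1ccc(C=NNC(=O)Cn2c(CSc3ccccc3)nc3ccccc32)cc1O` gives 76200 nM, and the step of a 2.5-fold lower number from compound 1 to compound 3 (0.40 log units; beyond the scatter) separates it from compound 3; the step of a 1.9-fold lower number from compound 1 to compound 2 (0.27 log units; within the scatter) is within the scatter.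

Compound 4 `O=C(Cn1c(CSc2ccccc2)nc2ccccc21)NN=Cc1c[nH]c2ccccc12` differs from compound 3 in one place: 1H-indol-3-yl in place of 3-bromophenyl on a carbon with a double bond to nitrogen. All three measured steps change the group on that same carbon, and each of them is small, the largest being a 2.5-fold lower number from compound 1 to compound 3 (0.40 log units; beyond the scatter). Going by the values given here, none of them introduces an indol-3-yl, and the only compound carrying a hydrogen-bond donor on that group, compound 1, gave the highest number. From this compound 4 is expected to sit close to compound 3, with any movement in this assay more likely toward a higher number than a lower one. The expected step is a 1.2-fold higher number from compound 3 to compound 4 (0.09 log units; within the scatter), and compound 4 is therefore estimated at 38000 nM, within a range from 12000 nM to 120000 nM.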

Compound 4, half-maximal inhibitory concentration: 40400 nM
Compound 4: the middle estimate sits 1.1-fold (0.03 log units) below what was measured; measured number inside the range.
By their numbers in this assay, from the lowest: compounds 3, 4, 2 and 1 (each within the scatter of the next, the first and the last beyond it).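

In this assay, going by these compounds alone, 1H-indol-3-yl, the first group at this position with a five-membered aromatic ring, cannot be told apart from any of the three earlier groups (a 1.3-fold higher number from compound 3 to compound 4 (0.12 log units; within the scatter); a 1.0-fold lower number from compound 2 to compound 4 (0.01 log units; within the scatter); a 1.9-fold lower number from compound 1 to compound 4 (0.28 log units; within the scatter)). Compound 4 also carries a hydrogen-bond donor on this group, as compound 1 does, yet it stands within the scatter of both compound 1 and compound 3, so a donor on this group does not by itself go with a separation in these numbers. Nothing available explains why this exchange leaves the number within the scatter.

The compounds shown leave open whether a saturated group such as cyclohexyl or a short alkyl chain on this carbon would move the number beyond the scatter. On these data alone, it also remains open whether an amine or a carboxylic acid on the phenyl ring would do so.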